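The compounds below may be only part of what the source reports. "The series", "measured", "known", "first", "only" and "open" are said of these compounds alone.

Measured compounds:
- compound 1, `CCNC(=S)SCC1=CCOC1=O`, 30600 nM
- compound 2, `CN(C)C(=S)SCC1=CCOC1=O`, 147000 nM
- compound 3, `CNC(=S)SCC1=CCOC1=O`, 76500 nM

In a functional assay on PC-3 cells (Homo sapiens) for antiproliferative activity, read by MTT assay, with a stated time of 72 h (a higher number here means a weaker inhibitor, a lower number a stronger inhibitor), compound 3 sits second highest of the three numbers: compound 1 gives a lower number, a gap beyond the scatter, while compound 2 and compound 3 lie within the scatter of each other. The unmeasured compound 4, `O=C1OCC=C1CSC(=S)NCc1ccccc1`, differs from compound 3 by one change: phenyl in place of hydrogen on a saturated chain carbon bound to an amide-type nitrogen. Among the measured compounds shown here, one measured step bears on this place. Going from compound 1 to compound 3 removed a methyl from the same saturated chain carbon, and the number rose, a 2.5-fold higher number from compound 1 to compound 3 (0.40 log units; beyond the scatter). Compound 4 goes the other way at that carbon, adding a phenyl rather than a methyl. For the measured compounds named here, since a larger group at this position gave the lower number in the one comparison available, compound 4 is expected to show a modestly lower number than compound 3 in this assay, a 3.1-fold lower number from compound 3 to compound 4 (0.49 log units; beyond the scatter). The estimate for compound 4 is 25000 nM, within a range from 8000 nM to 80000 nM.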

Compound 4, half-maximal inhibitory concentration: 13700 nM
For compound 4 the middle estimate is 1.8-fold (0.26 log units) above the measured one, within the range that was stated.
By their numbers in this assay, from the lowest: compound 4; then compound 1; then compounds 3 and 2 (each within the scatter of the next).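

In this assay, phenyl on the saturated chain carbon bound to an amide-type nitrogen goes further than methyl did: there is a 5.6-fold lower number from compound 3 to compound 4 (0.75 log units; beyond the scatter), and still a 2.2-fold lower number from compound 1 to compound 4 (0.35 log units; beyond the scatter). Across compound 3, compound 1 and compound 4, then, the number falls at each step from hydrogen to methyl to phenyl, so this carbon can carry a whole aromatic ring and the number still drops. Nothing available gives a reason for this trend.

On these data alone, it remains open whether the aromatic ring itself matters, since a propyl or butyl chain or a saturated cyclohexyl ring at this carbon would be needed to tell. Also open, as far as these compounds go, is how chlorine or a methoxy group on the phenyl would move the number.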